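Amide aryl exchange on a shared hydroxychromenone core

A few compounds are considered here, and "the series" means these few. Any claim that something is new, unique, unknown or untested is made for them only; others in the source may bear on it.

For the measured compounds named here, compound 2 `Cc1cc(C(=O)Nc2cccc(-c3oc4cc(-c5ccc(F)cc5)ccc4c(=O)c3O)c2)ccc1F` gives 7440 nM in a functional assay on MDA-MB-231 cells (Homo sapiens) for antiproliferative activity, read by CCK-8 assay, with a stated time of 72 h (on this read-out lower numbers stand for stronger inhibition and higher numbers for weaker inhibition), the lowest of the two numbers so far; its only neighbour is compound 1 `O=C(Nc1cccc(-c2oc3cc(-c4ccc(F)cc4)ccc3c(=O)c2O)c1)c1ccc(C(F)(F)F)cc1`, which gives 29400 nM. Going by the values given here, the one measured step, a 4.0-fold lower number from compound 1 to compound 2 (0.60 log units; beyond the scatter), shows that swapping the aryl on the carbonyl carbon moves the read-out by a modest but real amount. Compound 3 `N#Cc1ccc(C(=O)Nc2cccc(-c3oc4cc(-c5ccc(F)cc5)ccc4c(=O)c3O)c2)cc1` carries the change 4-cyanophenyl in place of 4-fluoro-3-methylphenyl on a carbonyl carbon at the same place. Among the compounds with values here, only the step from compound 1 to compound 2 bears on it, and it shows the size to expect for such an exchange but not its direction, since the entering 4-cyanophenyl matches neither of the aryls already measured. A step of roughly that size in either direction is therefore plausible, with the estimate set toward the higher side because compound 1 gave 29400 nM. For compound 3 the expected value is 15000 nM, within 5000 nM to 45000 nM, meaning an estimated 2.0-fold higher number from compound 2 to compound 3 (0.30 log units; within the scatter).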

Compound 3, half-maximal inhibitory concentration: 11600 nM
Estimate against measurement, compound 3: 1.3-fold (0.11 log units) above; the range from low to high includes it.
By their numbers in this assay, from the lowest: compounds 2 and 3 (each within the scatter of the next); then compound 1.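

In this assay 4-cyanophenyl in place of 4-fluoro-3-methylphenyl on the carbonyl carbon gives a 1.6-fold higher number from compound 2 to compound 3 (0.19 log units; within the scatter) and so does not separate these two aryls. Cyano in place of trifluoromethyl on the aromatic carbon gives a 2.5-fold lower number from compound 1 to compound 3 (0.40 log units; beyond the scatter) and is thus a second exchange, after the one leading to compound 2, that takes the number clearly down from that of compound 1. Of the three aryls, only the 4-(trifluoromethyl)phenyl of compound 1 now stands apart, with the highest number of the series.

On these data alone, what a carboxylic acid, an amine or a longer chain on this aryl would give remains open, as does whether any exchange at this place reaches much lower numbers. As far as these compounds go, the effect of changes elsewhere on the shared core also remains open. No evidence on the cause of these differences is available here.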